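The source may hold more compounds than are shown below. What is called first, only, known or untested is meant among the compounds shown, and "the series" means these compounds.

Measured in a functional assay on MCF7 cells (Homo sapiens) for antiproliferative activity, read by CCK-8 assay, with a stated time of 48 h; on this read-out higher numbers stand for weaker inhibition and lower numbers for stronger inhibition:
- compound 1 `C=C(C)C(=O)NCCOc1ccc(Oc2c(-c3ccc(F)cc3)sc3cc(O)ccc23)cc1`: > 25000 nM (a limit)
- compound 2 `O=C(CCCNCCOc1ccc(Oc2c(-c3ccc(F)cc3)sc3cc(O)ccc23)cc1)N1CCC1`: > 25000 nM (a limit)

Compound 2 gives only a limit, > 25000 nM. For the measured compounds named here, the series so far rests on (the limit of > 25000 nM in this assay, at which 2 of the 2 values shown sit). Compound 3 `O=C(/C=C/CNCCOc1ccc(Oc2c(-c3ccc(F)cc3)sc3cc(O)ccc23)cc1)N1CCCCC1` follows from compound 2 by 2-((piperidin-1-yl)carbonyl)ethenyl in place of 2-((azetidin-1-yl)carbonyl)ethyl on a saturated chain carbon bound to an amine nitrogen. Going by the values given here, the one measured step, a step that the two limits leave unreadable from compound 1 to compound 2, concerns the same amine nitrogen but offers no size to carry over. Only a small shift toward stronger inhibition in this assay is therefore expected, and another limit is about as likely as a number. The expected change is an at least 1.2-fold lower number from compound 2 to compound 3 (0.09 log units; that floor lies within the scatter). For compound 3 the estimate is 20000 nM, with an expected range of 6000 nM to 40000 nM.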

Compound 3, half-maximal inhibitory concentration: 16400 nM
Estimate against measurement, compound 3: 1.2-fold (0.09 log units) above; the measured number falls inside the stated range.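

In this assay, for the compounds shown here, compound 3 gives 16400 nM, the first value that is a number and not a limit. Replacing 2-((azetidin-1-yl)carbonyl)ethyl with 2-((piperidin-1-yl)carbonyl)ethenyl gives an at least 1.5-fold lower number from compound 2 to compound 3 (0.18 log units; that floor lies within the scatter), and the wider change on the amine nitrogen gives an at least 1.5-fold lower number from compound 1 to compound 3 (0.18 log units; that floor lies within the scatter). Both steps are floors only, and the rest of the series still sits at a limit: the limit of > 25000 nM in this assay, at which 2 of the 3 values shown sit.

As far as these compounds go, the step changes the ring and the double bond together, so their separate contributions remain open. From the compounds shown here alone, a pyrrolidine amide or a longer chain at this place also remains open.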